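A few compounds are considered here, and "the series" means these few. Any claim that something is new, unique, unknown or untested is made for them only; others in the source may bear on it.

Three purine-type compounds were tested in a functional assay on HCT-15 cells (Homo sapiens) for cytotoxicity, read by sulforhodamine B assay, with a stated time of 48 h; on this read-out higher numbers stand for weaker inhibition of growth and lower numbers for stronger inhibition of growth. Compound 1 `ClCc1ccccc1Cn1cnc2c(Cl)nc(Cl)nc21` gives 1200 nM, compound 2 `ClCc1ccccc1Cn1cnc2c(Cl)ncnc21` gives 4670 nM, and compound 3 `ClCc1cccc(Cn2cnc3ncnc(Cl)c32)c1` gives 4360 nM. Compound 2 and compound 3 share the same atoms joined differently; the difference between the two cores is not broken down here, and their values lie within the scatter of each other. The change from compound 2 to compound 1, (chloro in place of hydrogen on an aromatic carbon), gave a 3.9-fold lower number from compound 2 to compound 1 (0.59 log units; beyond the scatter). Compound 4 `ClCc1cccc(Cn2cnc3nc(Cl)nc(Cl)c32)c1` carries the same change made on compound 3, (chloro in place of hydrogen on an aromatic carbon), at a place described in identical terms. On that one earlier step alone, compound 4 is expected to show a 3.6-fold lower number from compound 3 to compound 4 (0.56 log units; beyond the scatter), because compound 3 stands at 4360 nM and the earlier step was a 3.9-fold lower number from compound 2 to compound 1 (0.59 log units; beyond the scatter). The estimate for compound 4 in this assay is therefore 1200 nM, between 550 nM and 2700 nM.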

Compound 4, concentration for total growth inhibition: 2130 nM
Estimate against measurement, compound 4: 1.8-fold (0.25 log units) below, and the stated range covers the measured number.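

In this assay, chloro in place of hydrogen on an aromatic carbon gave a 2.0-fold lower number from compound 3 to compound 4 (0.31 log units; beyond the scatter) and so pushed the number the same way as on the other core. Set side by side, the two steps do not differ by more than the scatter: the same change on two cores in this assay, a 3.9-fold lower number (0.59 log units; beyond the scatter) from compound 2 to compound 1 and a 2.0-fold lower number (0.31 log units; beyond the scatter) from compound 3 to compound 4, 1.9-fold (0.28 log units) apart, within the scatter of two such steps. This shows that the change carried over between these two cores in direction and, within the scatter, in size, but two pairs cannot show that it would carry over to any other core, and they do not explain how the change acts.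

The compounds shown leave open whether an amine or a methoxy group on that aromatic carbon, between two ring nitrogen atoms, would act as chloro does.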